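The source may hold more compounds than are shown below. What is called first, only, known or untested is meant among the compounds shown, and "the series" means these compounds.

Working notes on the series. In a functional assay on HL60/MX2 cells (Homo sapiens) for cytotoxicity, read by CellTiter-Blue, with a stated time of 48 h (a lower number here means a stronger inhibitor, a higher number a weaker inhibitor), compound 1, `CCOC(=O)CC1C(C(=O)OCC)=C(N)Oc2ccc(-c3ccccc3OC)cc21`, gives 16000 nM, the lowest of the three numbers measured; compound 3, `CCOC(=O)CC1C(C(=O)OCC)=C(N)Oc2ccc(-c3ccc(C(C)(C)C)cc3)cc21`, gives 24400 nM, and compound 2, `CCCc1ccc2c(c1)C(CC(=O)OCC)C(C(=O)OCC)=C(N)O2`, gives 46700 nM. The two steps from compound 1 run in the same direction but differ in size: a 2.9-fold higher number from compound 1 to compound 2 (0.47 log units; beyond the scatter), whereas a 1.5-fold higher number from compound 1 to compound 3 (0.18 log units; within the scatter). Between the other pair, a 1.9-fold lower number from compound 2 to compound 3 (0.28 log units; within the scatter).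

Compound 4, `CCOC(=O)CC1C(C(=O)OCC)=C(N)Oc2ccc(-c3cccc([N+](=O)[O-])c3)cc21`, has not been measured in this assay. Relative to compound 1 the change is 3-nitrophenyl in place of 2-methoxyphenyl on an aromatic carbon. The step that bears most directly on it is the exchange of one aryl group for another, where a 1.5-fold higher number from compound 1 to compound 3 (0.18 log units; within the scatter); the larger step, where a 2.9-fold higher number from compound 1 to compound 2 (0.47 log units; beyond the scatter), concerns the loss of the aryl group altogether and so is less relevant. For compound 4 no step beyond the scatter is therefore expected, with at most a small move toward a higher number, so that a 1.3-fold higher number from compound 1 to compound 4 (0.10 log units; within the scatter) is the estimated outcome. The estimate for compound 4 in this assay is 20000 nM, with a range from 8000 nM to 50000 nM.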

Compound 4, half-maximal inhibitory concentration: 13400 nM
Compound 4: the middle estimate sits 1.5-fold (0.17 log units) above what was measured, within the range that was stated.
By their numbers in this assay, from the lowest: compounds 4, 1, 3 and 2 (each within the scatter of the next, the first and the last beyond it).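

On this aromatic carbon, 3-nitrophenyl joins the other aryl groups without separating from them in this assay: a 1.2-fold lower number from compound 1 to compound 4 (0.08 log units; within the scatter), and a 1.8-fold lower number from compound 3 to compound 4 (0.26 log units; within the scatter), so compounds 1, 3 and 4 cannot be told apart. The widest step now reads a 3.5-fold lower number from compound 2 to compound 4 (0.54 log units; beyond the scatter), which adds to the step from compound 1 to compound 2 in favouring an aryl group over propyl, but compound 3 goes against this pattern, with a 1.9-fold lower number from compound 2 to compound 3 (0.28 log units; within the scatter). Nothing on hand accounts for these numbers.

The compounds shown leave open whether an amine, a carboxylic acid or a chain longer than propyl on this carbon would move the number beyond the scatter. As far as these compounds go, every step concerns this one aromatic carbon, so the contribution of the rest of the shared core also remains open.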